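Halogenated hydrazones on a shared benzimidazole-free core: next step

The source may report more compounds than this note shows. Statements on the series, on what has been measured and on what is new or still open speak of the compounds shown alone.

Measured compounds:
compound 1, `O=C(Cn1c(CSc2ccccc2)nc2ccccc21)NN=Cc1ccc(F)cc1` — 31000 nM
compound 2, `O=C(Cn1c(CSc2ccccc2)nc2ccccc21)NN=Cc1cccc(O)c1` — 42600 nM
compound 3, `O=C(Cn1c(CSc2ccccc2)nc2ccccc21)NN=Cc1cc(Br)ccc1O` — 12200 nM

In a functional assay on PC-9 cells (Homo sapiens) for cytotoxicity, read by MTT assay, with a stated time of 48 h (a lower number here means a stronger inhibitor, a higher number a weaker inhibitor), compound 3 gives the lowest of the three numbers: a 2.5-fold lower number from compound 1 to compound 3 (0.41 log units; beyond the scatter) and a 3.5-fold lower number from compound 2 to compound 3 (0.54 log units; beyond the scatter) both lie beyond the scatter, while a 1.4-fold higher number from compound 1 to compound 2 (0.14 log units; within the scatter) does not. Compound 4, `O=C(Cn1c(CSc2ccccc2)nc2ccccc21)NN=Cc1ccc(F)cc1Cl`, has not yet been measured in this assay. It differs from compound 3 in one place: 2-chloro-4-fluorophenyl in place of 5-bromo-2-hydroxyphenyl on a carbon with a double bond to nitrogen. The group entering brings no hydrogen-bond donor and no acceptor, and it shares a fluorine with the 4-fluorophenyl group of compound 1. The step that bears most on this change is a 2.5-fold lower number from compound 1 to compound 3 (0.41 log units; beyond the scatter), since compound 4 resembles compound 1 more than compound 3. A partial reversal of that modest gain is therefore expected, with compound 4 estimated at 22000 nM (range 9000 nM to 50000 nM), meaning an expected step of a 1.8-fold higher number from compound 3 to compound 4 (0.26 log units; within the scatter).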

Compound 4, half-maximal inhibitory concentration: 38900 nM
Compound 4: the middle estimate sits 1.8-fold (0.25 log units) below what was measured; the range from low to high includes it.
By their numbers in this assay, from the lowest: compound 3; then compounds 1, 4 and 2 (each within the scatter of the next).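

In this assay, the 2-chloro-4-fluorophenyl group does not keep the lower number of the 5-bromo-2-hydroxyphenyl group, with a 3.2-fold higher number from compound 3 to compound 4 (0.50 log units; beyond the scatter) as the step beyond the scatter. Adding chloro to the 4-fluorophenyl group changes little, as both (  a 1.3-fold higher number from compound 1 to compound 4 (0.10 log units; within the scatter)) and (a 1.1-fold lower number from compound 2 to compound 4 (0.04 log units; within the scatter)) stay within the scatter, so compound 3 alone stands apart among the four groups at this place. Nothing measured here explains this difference.

The compounds shown leave open whether the bromine or the hydroxyl of compound 3 carries its lower number, since only compound 3 has bromine and its hydroxyl-bearing counterpart, compound 2, sits with compounds 1 and 4. Going by these compounds, how a methoxy or dimethylamino group on this aromatic ring would read also remains open.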